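Chloro in Place of Hydrogen: Expected Tolerance of Compound 3

This account rests on a few compounds, and the source may have more. Where it says the series, first, only, none or still open, it means among the compounds named here.

Measured compounds:
compound 1 `N#Cc1cc2c(Oc3ccc(F)cc3OCCn3ccc(=O)[nH]c3=O)cc(F)cn2c1` — 50000 nM
compound 2 `N#Cc1ccc2ccc(Oc3ccccc3OCCn3ccc(=O)[nH]c3=O)cc2c1` — 15000 nM

In a toxicity assay on MT2 cells (Homo sapiens) for cytotoxicity, read by MTT assay (a higher number here means that more compound is tolerated, a lower number that less compound is tolerated), compound 1 gives 50000 nM, while compound 2 gives 15000 nM. Of the two numbers, compound 2 stands lowest; its nearest neighbour is compound 1, whose higher number lies beyond the scatter, so less of compound 2 is tolerated than of compound 1. Going by the values given here, no pair of measured compounds shares a single point of difference, so no measured step is available.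

Compound 3 `N#Cc1ccc2c(Cl)cc(Oc3ccccc3OCCn3ccc(=O)[nH]c3=O)cc2c1` differs from compound 2 in one place: chloro in place of hydrogen on an aromatic carbon. Among the compounds with values here, nothing among the measured compounds shows what this change does in this assay. The step from compound 2 to compound 3 is therefore expected to be modest, a 1.5-fold lower number from compound 2 to compound 3 (0.18 log units; within the scatter), leaning toward a slightly lower number but most likely staying within the scatter of repeated measurements. Compound 3 is estimated at 10000 nM, with a range from 4000 nM to 30000 nM.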

Compound 3, half-maximal cytotoxic concentration: 12000 nM
For compound 3 the middle estimate is 1.2-fold (0.08 log units) below the measured one, and the stated range covers the measured number.
By their numbers in this assay, from the lowest: compounds 3 and 2 (each within the scatter of the next); then compound 1.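

Going by these compounds alone, the step of a 1.3-fold lower number from compound 2 to compound 3 (0.10 log units; within the scatter) is the first single-place change that can be read in this assay, and it shows that chloro in place of hydrogen on this aromatic carbon, ortho to a fused ring and meta to a large group, leaves compound 3 within the scatter of compound 2. One added chlorine atom at this position therefore gives no readable shift in tolerance, which the two earlier compounds could not show. No measurement among the data accounts for this outcome.

On these data alone, whether this position stays as silent with other groups, such as an amine, a carboxylic acid or a methoxy group, remains open. As far as these compounds go, it is also open whether chloro would give the same result at another aromatic carbon or on the core of compound 1.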